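The source may report more compounds than this note shows. Statements on the series, on what has been measured and on what is new or still open speak of the compounds shown alone.

Measured so far:
Compound 1 `COc1cc(/C=C/C(=O)C(=Cc2ccccc2)C(=O)/C=C/c2ccc(O)c(OC)c2)ccc1O`: 84400000 nM
Compound 2 `CCOc1cc(/C=C/C(=O)C(=Cc2ccc(O)c(OC)c2)C(=O)/C=C/c2ccc(O)c(OCC)c2)ccc1O`: 60500000 nM

Both numbers come from a functional assay, read by spectrophotometry, with a stated time of 5 min; a lower number here means a stronger inhibitor, a higher number a weaker inhibitor. Compound 2 has the lower of the two numbers, but its value lies within the usual scatter of the value of compound 1, so the pair cannot be told apart as inhibitors.

Compound 3 `CCOc1cc(C=C(C(=O)/C=C/c2ccc(O)c(OCC)c2)C(=O)/C=C/c2ccc(O)c(OCC)c2)ccc1O` has not yet been measured. It differs from compound 2 by one change: methyl in place of hydrogen on a saturated chain carbon bound to an oxygen on an aromatic ring. This places methyl in place of hydrogen on a saturated chain carbon bound to an oxygen on an aromatic ring, turning methoxy to ethoxy. Going by the values given here, no measured pair shows this change alone, so no step beyond the scatter is expected in this assay, and neither direction is favoured. The expected step is a 1.0-fold lower number from compound 2 to compound 3 (0.00 log units; within the scatter). For compound 3 the estimated value is 60000000 nM, with an expected range of 25000000 nM to 140000000 nM.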

Compound 3, half-maximal inhibitory concentration: 96700000 nM
Estimate against measurement, compound 3: 1.6-fold (0.21 log units) below; the measured number falls inside the stated range.
By their numbers in this assay, from the lowest: compounds 2, 1 and 3 (each within the scatter of the next).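

Going by these compounds alone, this is the first pair that differs in one place only, so it gives the first direct reading of methoxy to ethoxy, with methyl in place of hydrogen on a saturated chain carbon bound to an oxygen on an aromatic ring. In this assay, this change gives a 1.6-fold higher number from compound 2 to compound 3 (0.20 log units; within the scatter), so the two cannot be told apart as inhibitors, and ethoxy at this place shows no measurable difference from methoxy. Nothing measured here offers an explanation for this result.

Going by these compounds, only methoxy and ethoxy are compared in this pair, so a longer chain such as butoxy, or an amine or a carboxylic acid at the same place, remains open. On these data alone, whether the same change would read the same way on the core of compound 1 also remains open.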